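This account rests on a few compounds, and the source may have more. Where it says the series, first, only, none or still open, it means among the compounds named here.

Compound 1 `Nc1cc(N)c2nc(-c3ccccc3)c(Oc3ccc(Cl)c(Cl)c3)nc2c1` carries a 3,4-dichlorophenoxy group on its shared core. In a functional assay on SK-MEL-5 cells (Homo sapiens) for inhibition, read by sulforhodamine B assay, with a stated time of 48 h (on this read-out lower numbers stand for stronger inhibition of growth and higher numbers for weaker inhibition of growth), compound 1 gives 9770 nM. Among the compounds with values here, the only other measured compound, compound 2 `CCOC(=O)[C@H](CCC(=O)O)NC(=O)c1ccc(Oc2nc3cc(N)cc(N)c3nc2-c2ccccc2)cc1`, gives 18200 nM in this assay; the two numbers lie within the usual scatter of each other, so neither compound can be called the stronger inhibitor of growth. Compound 3 `Nc1cc(N)c2nc(-c3ccccc3)c(Sc3ccc(Cl)c(Cl)c3)nc2c1` has not yet been measured. It differs from compound 1 by (3,4-dichlorophenyl)sulfanyl in place of 3,4-dichlorophenoxy on an aromatic carbon: the oxygen that joins the dichlorinated ring to the core is exchanged for sulfur, and everything else stays the same. Within the data shown here, no pair of measured compounds shows the result of such an exchange, so there is no step to lean on. A swap of this kind is expected to move the number only slightly, with no step beyond the scatter in either direction. Compound 3 is therefore estimated to give 8000 nM in this assay, somewhere between 2500 nM and 25000 nM, which amounts to an expected step of a 1.2-fold lower number from compound 1 to compound 3 (0.09 log units; within the scatter).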

Compound 3, concentration for 50% growth inhibition: 21400 nM
For compound 3 the middle estimate is 2.7-fold (0.43 log units) below the measured one; the range from low to high includes it.
By their numbers in this assay, from the lowest: compounds 1, 2 and 3 (each within the scatter of the next, the first and the last beyond it).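

In this assay, the atom joining the dichlorinated ring to the shared core is not a neutral detail: (3,4-dichlorophenyl)sulfanyl in place of 3,4-dichlorophenoxy gives a 2.2-fold higher number from compound 1 to compound 3 (0.34 log units; beyond the scatter) on this one pair. The step is modest, but it lies beyond the usual scatter, so compound 1, with the oxygen link, is the stronger inhibitor of growth of the two. Nothing measured here accounts for this difference.

Still open, as far as these compounds go, is how an amine or methylene link would compare with oxygen and sulfur at this same aromatic carbon. From the compounds shown here alone, it is also open whether the exchange of oxygen for sulfur would give a step of similar size and direction on a different ring, such as the substituted phenyl ring of compound 2.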